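Thienopyrimidine styryl series: amine substituent variation

The source may report more compounds than this note shows. Statements on the series, on what has been measured and on what is new or still open speak of the compounds shown alone.

Measured compounds in a functional assay on L02 cells (Homo sapiens) for inhibition, read by Griess assay, with stated times of 1 h and 24 h; a lower number here means a stronger inhibitor, a higher number a weaker inhibitor:
compound 1 `CCN1CCN(c2nc(/C=C/c3cc(OC)c(OC)c(OC)c3)nc3ccsc23)CC1`, > 1000000 nM
compound 2 `COc1cc(/C=C/c2nc(Nc3ccc(C)cc3)c3sccc3n2)cc(OC)c1OC`, < 40000 nM
compound 3 `COc1ccc(Nc2nc(/C=C/c3cc(OC)c(OC)c(OC)c3)nc3ccsc23)cc1`, 279000 nM

Compound 1 gives only a limit of this assay, > 1000000 nM. Compound 2 likewise gives only a limit, < 40000 nM. Compound 3, at 279000 nM, is the sole compound with a number shown. Compounds 1 and 2 sit at limits (the limit of < 40000 nM in this assay, at which 1 of the 3 values shown sits, (the limit of > 1000000 nM in this assay, at which 1 of the 3 values shown sits)).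

Compound 4 `COc1cc(/C=C/c2nc(NCc3ccccc3)c3sccc3n2)cc(OC)c1OC` differs from compound 3 by benzyl in place of 4-methoxyphenyl on a nitrogen on an aromatic ring. All three measured steps bear on this position: an at least 25-fold lower number from compound 1 to compound 2 (1.39 log units; beyond the scatter), an at least 3.5-fold lower number from compound 1 to compound 3 (0.55 log units; beyond the scatter), and an at least 6.9-fold higher number from compound 2 to compound 3 (0.84 log units; beyond the scatter). Replacing the amino substituent has shifted this assay across a wide span, so the step to compound 4 may well exceed the scatter, though the direction is uncertain. A modest move toward the stronger end is expected, a 1.9-fold lower number from compound 3 to compound 4 (0.27 log units; within the scatter). Compound 4 is estimated at 150000 nM, within 30000 nM to 800000 nM.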

Compound 4, half-maximal inhibitory concentration: > 1000000 nM
Compound 4: no number, only a limit (the forecaster's own chance of this, stated with the estimate: 30%); middle value at least 6.6-fold (0.82 log units) from the limit.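

In this assay compound 4 gives only a limit, not a number: the limit of > 1000000 nM in this assay, at which 2 of the 4 values shown sit.

Keeping a six-membered aromatic ring on this nitrogen is therefore not enough to hold the values of the anilines: benzyl in place of 4-methoxyphenyl gives an at least 3.5-fold higher number from compound 3 to compound 4 (0.55 log units; beyond the scatter), and benzyl in place of 4-methylphenyl gives an at least 25-fold higher number from compound 2 to compound 4 (1.39 log units; beyond the scatter). The step between compound 1 and compound 4 cannot be read, as both are limits.

Open, from the compounds shown here alone, is how a 2-phenylethyl or 4-methoxybenzyl group on this nitrogen would read, and whether an unsubstituted phenyl would sit with compound 2 and compound 3. Going by these compounds, with compound 2 and compound 4 both at limits, the true size of the step between them also stays open.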